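Swapping a Nitro-Bearing Aryl for a Difluorophenyl Ring

The compounds below may be only part of what the source reports. "The series", "measured", "known", "first", "only" and "open" are said of these compounds alone.

Compound 1, `COc1cc(C2=NN(C(C)=O)C(c3ccc(Cl)c(Cl)c3)O2)cc(OC)c1OC`: 28.1%
Compound 2, `COc1cc(C2=NN(C(C)=O)C(c3ccc(Cl)c([N+](=O)[O-])c3)O2)cc(OC)c1OC`: 43.3%

Of the compounds shown here, two have been measured in a functional assay on PC-3 cells (Homo sapiens) for antiproliferative activity, read by MTT assay, tested at 1 uM; a lower number here means a weaker effect, a higher number a stronger effect of the compound at the concentration tested. For the measured compounds named here, compound 2 gives 43.3%, the higher of the two numbers; its nearest neighbour, compound 1, gives 28.1%, and the single recorded step is a number 15.2 percentage points higher from compound 1 to compound 2 (beyond the scatter). Compound 3, `COc1cc(C2=NN(C(C)=O)C(c3ccc(F)c(F)c3)O2)cc(OC)c1OC`, has not yet been measured. It differs from compound 2 in one place: 3,4-difluorophenyl in place of 4-chloro-3-nitrophenyl on a saturated ring carbon. The recorded step bears on this change: the nitro group that entered between compound 1 and compound 2 leaves again here, with fluorine rather than chlorine in both halogen places. That step, a number 15.2 percentage points higher from compound 1 to compound 2 (beyond the scatter), was modest and beyond the scatter, so a drop of comparable size is the natural expectation. The expected step is a number 13.3 percentage points lower from compound 2 to compound 3 (beyond the scatter). Nothing measured tells how fluorine compares with chlorine, so the range is wide. Compound 3 is therefore estimated at about 30%, between 15% and 45%.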

Compound 3, a percentage reported as inhibition, at one concentration (the size of the read-out at that concentration, not a potency): 35.5%
For compound 3 the middle estimate is 5.5 percentage points below the measured one; the range from low to high includes it.
By their numbers in this assay, from the lowest: compounds 1, 3 and 2 (each within the scatter of the next, the first and the last beyond it).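

In this assay the exchange of 4-chloro-3-nitrophenyl for 3,4-difluorophenyl gives a number 7.8 percentage points lower from compound 2 to compound 3 (within the scatter) and the exchange of 3,4-dichlorophenyl for 3,4-difluorophenyl gives a number 7.4 percentage points higher from compound 1 to compound 3 (within the scatter) as its step. The saturated ring carbon therefore carries a ring without a nitro group and still gives a number within the scatter of compound 2, so the nitro group is not required for that, even though compound 1 and compound 2 lie beyond the scatter of each other. Nothing at hand accounts for these numbers.

As far as these compounds go, what an amine or a carboxylic acid on this aryl ring would give remains open. So does the effect of all these compounds at any other concentration: each number gives the size of the effect at a single concentration.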